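Cyclohexyl substituent variation and Vero cell cytotoxicity

The source may report more compounds than this note shows. Statements on the series, on what has been measured and on what is new or still open speak of the compounds shown alone.

Compound 1 `CCCC(=O)OC1CCC(CN2CCN(c3cc(=O)c4cc(C(F)(F)F)cc([N+](=O)[O-])c4s3)CC2)CC1` is characterised in an ADME assay on Vero cells (Chlorocebus sabaeus) for cytotoxicity, read by MTT assay, with a stated time of 48 h; on this read-out higher numbers stand for weaker inhibition and lower numbers for stronger inhibition. In this assay compound 1 reaches only a limit, > 64 ug/mL. Compound 2 `O=C(OC1CCC(CN2CCN(c3cc(=O)c4cc(C(F)(F)F)cc([N+](=O)[O-])c4s3)CC2)CC1)c1cccs1` likewise reaches only a limit in this assay, > 64 ug/mL. Compound 3 `O=c1cc(N2CCN(CC3CCC(NS(=O)(=O)c4ccccc4)CC3)CC2)sc2c([N+](=O)[O-])cc(C(F)(F)F)cc12` also returns only a limit in this assay, > 64 ug/mL. All three sit at the limit of > 64 ug/mL in this assay, at which 3 of the 3 values shown sit, so compound 3 stands together with the other two as far as the numbers go, and none can be ranked against another. The steps a step that the two limits leave unreadable from compound 1 to compound 3 and a step that the two limits leave unreadable from compound 2 to compound 3 are thus unreadable in size, as is a step that the two limits leave unreadable from compound 1 to compound 2.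

Compound 4 `O=C(OC1CCC(CN2CCN(c3cc(=O)c4cc(C(F)(F)F)cc([N+](=O)[O-])c4s3)CC2)CC1)c1ccc2c(c1)OCC2` remains to be measured. It differs from compound 3 as follows: a group of 12 heavy atoms (9 carbon, 3 oxygen; one five-membered non-aromatic ring with 1 hetero atom, one six-membered aromatic ring of carbon only) in place of a group of 10 heavy atoms (6 carbon, 1 nitrogen, 2 oxygen, 1 sulfur; one six-membered aromatic ring of carbon only), on a saturated ring carbon The entering group is again an ester on the saturated ring carbon, as in compound 1 and compound 2, both of which ended at the limit. Among the compounds with values here, no measured step offers a readable size, so no shift beyond the scatter is expected; the step that the limit leaves unreadable from compound 3 to compound 4 is the estimate. Compound 4 is expected at 80 ug/mL, within 40 ug/mL to 200 ug/mL, most probably reported once more as a limit.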

Compound 4, half-maximal inhibitory concentration: > 64 ug/mL
Compound 4: only a limit was reported; the forecaster's own chance of this, stated with the estimate: 80%; the middle value is on the limit's open side.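

In this assay compound 4 gives only a limit, > 64 ug/mL. No step among compound 1, compound 2, compound 3 and compound 4 can be read: the limit of > 64 ug/mL in this assay, at which 4 of the 4 values shown sit.

The compounds shown leave open whether any of these groups on the saturated ring carbon separates one compound from another in this assay.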